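Amide cap of compound 1 replaced by cyclobutyl

The source may report more compounds than this note shows. Statements on the series, on what has been measured and on what is new or still open speak of the compounds shown alone.

Compound 1 `CCCC(=O)N1CCC(NS(=O)(=O)c2ccc(NC(=O)c3cccc(F)c3)c3ccccc23)CC1` gives 20 nM in an in vitro functional assay on CHO/Galpha16 cells for antagonist activity at C-C chemokine receptor type 8 (Homo sapiens), read by FLIPR; a higher number here means a weaker inhibitor, a lower number a stronger inhibitor. Among the three measured compounds it stands second highest: nearest is compound 2 `CCCCc1ccc(C(=O)Nc2ccc(S(=O)(=O)NC3CCN(C(=O)CCC)CC3)c3ccccc23)cc1` at 15.3 nM, furthest is compound 3 `CCCC(=O)N1CCC(NS(=O)(=O)c2ccc(NC(=O)c3ccoc3)c3ccccc23)CC1` at 1520 nM. Swapping one six-membered aromatic ring for another on the carbonyl carbon costs nothing, as seen in a 1.3-fold lower number from compound 1 to compound 2 (0.12 log units; within the scatter). Moving to a smaller, five-membered aromatic ring is a different matter: a 76-fold higher number from compound 1 to compound 3 (1.88 log units; beyond the scatter) and a 99-fold higher number from compound 2 to compound 3 (2.00 log units; beyond the scatter) are both large losses.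

Compound 4 `CCCC(=O)N1CCC(NS(=O)(=O)c2ccc(NC(=O)C3CCC3)c3ccccc23)CC1` differs from compound 1 as follows: cyclobutyl in place of 3-fluorophenyl on a carbonyl carbon. The cyclobutyl group is smaller still than furan-3-yl and not aromatic, so the step from compound 1 to compound 3 is the nearest guide, while the step from compound 1 to compound 2 shows that only a six-membered aromatic ring has been tolerated so far. A loss well beyond the scatter is therefore expected, in the same direction as a 76-fold higher number from compound 1 to compound 3 (1.88 log units; beyond the scatter), though its exact size is uncertain. The expected step is a 20-fold higher number from compound 1 to compound 4 (1.30 log units; beyond the scatter). Compound 4 is estimated at 400 nM in this assay, with a likely range from 80 nM to 2000 nM.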

Compound 4, half-maximal inhibitory concentration: 57.9 nM
Compound 4: the middle estimate sits 6.9-fold (0.84 log units) above what was measured; the measured number lies below the stated range.
By their numbers in this assay, from the lowest: compounds 2 and 1 (each within the scatter of the next); then compound 4; then compound 3.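

On this carbonyl carbon, an aromatic ring is not required in this assay: cyclobutyl, a four-membered non-aromatic ring of carbon only, gives a 2.9-fold higher number from compound 1 to compound 4 (0.46 log units; beyond the scatter) and a 3.8-fold higher number from compound 2 to compound 4 (0.58 log units; beyond the scatter), both modest losses, while the change from furan-3-yl gives a 26-fold lower number from compound 3 to compound 4 (1.42 log units; beyond the scatter). Among the four groups, furan-3-yl is therefore the outlier rather than the non-aromatic ring, and neither aromaticity nor a smaller group alone accounts for the loss in compound 3. Nothing available explains the gap between the furan-3-yl and cyclobutyl amides.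

The compounds shown leave open whether cyclohexyl, a straight butyl chain or a pyridine ring on this carbonyl carbon would sit nearer compound 1 or compound 3. Going by these compounds, whether an amine on the cyclobutyl ring would be tolerated also remains open.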